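Thiourea series: aryl to butyl on the thiourea nitrogen

The source may hold more compounds than are shown below. What is called first, only, known or untested is meant among the compounds shown, and "the series" means these compounds.

Measured so far:
compound 1 `COc1cc2c(cc1OC)C(=O)C(CC1CCN(C(=S)Nc3ccccc3)CC1)C2` — 100 mg/kg
compound 2 `COc1cc2c(cc1OC)C(=O)C(CC1CCN(C(=S)Nc3ccccc3C)CC1)C2` — 300 mg/kg
compound 3 `COc1cc2c(cc1OC)C(=O)C(CC1CCN(C(=S)Nc3ccc(C)cc3)CC1)C2` — 100 mg/kg

In a functional assay on the whole organism (strain Swiss albino) with Mus musculus as the target, with a stated time of 0.5 h (on this read-out lower numbers stand for an effect already at smaller amounts and higher numbers for an effect only at larger amounts of compound), compound 3 gives 100 mg/kg. For the measured compounds named here, compound 3 stands level with compound 1 at the digits printed, and together they hold the lowest number of the three; the shift a 3.0-fold lower number from compound 2 to compound 3 (0.48 log units; beyond the scatter) is the only one that separates compound 3 from another compound beyond the scatter. The measured steps, a 3.0-fold higher number from compound 1 to compound 2 (0.48 log units; beyond the scatter) and no change at the digits printed from compound 1 to compound 3 (within the scatter), both concern a methyl in place of hydrogen on an aromatic carbon of the ring attached to the thiourea nitrogen.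

Compound 4 `CCCCNC(=S)N1CCC(CC2Cc3cc(OC)c(OC)cc3C2=O)CC1` is not yet measured. The change is butyl in place of 4-methylphenyl on an amide-type nitrogen. Going by the values given here, no measured step bears on this change: every step so far keeps the aromatic ring and moves only a methyl on it, whereas here the whole 4-methylphenyl leaves and a butyl chain enters. The data give no ground to expect a step in either direction beyond the scatter, so the expectation is no change at the digits printed from compound 3 to compound 4 (within the scatter), with a wide range. Compound 4 is therefore expected to give 100 mg/kg, estimated between 30 mg/kg and 300 mg/kg.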

Compound 4, minimum effective dose: 100 mg/kg
For compound 4 middle estimate and measured number coincide at the digits printed; measured number inside the range.
By their numbers in this assay, from the lowest: compounds 1, 3 and 4 (each within the scatter of the next); then compound 2.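

In this assay, an aromatic ring on the amide-type nitrogen is not required to hold the number: butyl in place of 4-methylphenyl gives no separation (no change at the digits printed from compound 3 to compound 4 (within the scatter)), and butyl in place of phenyl gives none either (no change at the digits printed from compound 1 to compound 4 (within the scatter)). Compound 2 therefore remains the only compound apart, now also against the butyl compound (a 3.0-fold lower number from compound 2 to compound 4 (0.48 log units; beyond the scatter)), so compounds 1, 3 and 4 stand level while 2-methylphenyl goes against any reading that this position tolerates every group shown. No available evidence accounts for this tolerance.

Open, going by these compounds, is how far the tolerance extends along the chain, from methyl to a longer chain such as octyl. Also open, on these data alone, is whether a butyl chain ending in an amine or a carboxylic acid, or a benzyl group, would hold the same number.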